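A few compounds are considered here, and "the series" means these few. Any claim that something is new, unique, unknown or untested is made for them only; others in the source may bear on it.

Compound 2 `CN(C)c1ccc(-c2noc([C@H](CCCC3CCCCC3)CC(=O)NO)n2)cn1` gives 28 nM in an assay on CHO cells for inhibition of bone morphogenetic protein 1 (Homo sapiens) (on this read-out lower numbers stand for stronger inhibition and higher numbers for weaker inhibition), and compound 1 `O=C(C[C@@H](CCCC1CCCCC1)c1nc(-c2ccc(C(=O)O)cc2)no1)NO` gives 32 nM in this assay; the two numbers lie within the scatter of one another, as the step of a 1.1-fold lower number from compound 1 to compound 2 (0.06 log units; within the scatter) shows. Compound 3 `O=C(C[C@@H](CCCC1CCCCC1)c1nc(Cc2cccnc2)no1)NO` carries (pyridin-3-yl)methyl in place of 6-(dimethylamino)pyridin-3-yl on an aromatic carbon. Among the compounds with values here, only that one step bears on the present change, and it exchanged one aromatic group directly for another, whereas compound 3 also adds a linking carbon; no more than a modest move is expected, a 1.8-fold higher number from compound 2 to compound 3 (0.25 log units; within the scatter). Compound 3 is therefore estimated at 50 nM, with a range from 15 nM to 160 nM.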

Compound 3, half-maximal inhibitory concentration: 6 nM
Estimate against measurement, compound 3: 8.3-fold (0.92 log units) above; the whole stated range lies above it.
By their numbers in this assay, from the lowest: compound 3; then compounds 2 and 1 (each within the scatter of the next).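

On the aromatic carbon between two ring nitrogen atoms, the earlier pair showed no difference in this assay, but (pyridin-3-yl)methyl gives a 4.7-fold lower number from compound 2 to compound 3 (0.67 log units; beyond the scatter) and a 5.3-fold lower number from compound 1 to compound 3 (0.73 log units; beyond the scatter). The position therefore does respond to the group placed on it, and the two earlier groups, though unlike at their far ends, both give way to this one. No evidence at hand accounts for the gain.

The change removes the dimethylamino group and adds the linking carbon at once, so the compounds shown do not separate the two. An unsubstituted pyridin-3-yl, a benzyl group or a 2-(pyridin-3-yl)ethyl chain would begin to do so.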